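This account rests on a few compounds, and the source may have more. Where it says the series, first, only, none or still open, it means among the compounds named here.

In an ADME assay on MT4 cells (Homo sapiens) for cytotoxicity, read by MTT assay (on this read-out lower numbers stand for higher toxicity in this test and higher numbers for lower toxicity in this test), compound 2 (`Cc1cc(C)cc(S(=O)(=O)c2c(C(=O)NC(C)C(=O)NC(C)c3ccccc3)[nH]c3ccc(Cl)cc23)c1`) gives 21700 nM and compound 1 (`Cc1cc(C)cc(S(=O)(=O)c2c(C(=O)NCC(=O)NC(C)c3ccccc3)[nH]c3ccc(Cl)cc23)c1`) gives 29400 nM, two numbers that stand within the scatter of each other. Compound 3 (`Cc1cc(C)cc(S(=O)(=O)c2c(C(=O)NC(c3ccc(Cl)cc3)C3CC3)[nH]c3ccc(Cl)cc23)c1`) is reported only as a limit, > 47300 nM. Compound 4 (`Cc1cc(C)cc(S(=O)(=O)c2c(C(=O)NC(C)C(=O)NC(C)c3ccccc3F)[nH]c3ccc(Cl)cc23)c1`) departs from compound 2 by fluoro in place of hydrogen on an aromatic carbon, which is fluoro in place of hydrogen on an aromatic carbon. Going by the values given here, two measured steps bear on this change, though neither makes the same swap: a 1.4-fold lower number from compound 1 to compound 2 (0.13 log units; within the scatter) and an at least 1.6-fold higher number from compound 1 to compound 3 (0.20 log units; that floor lies within the scatter). With both of these small, no step beyond the scatter is expected in this assay. The expected step is a 1.1-fold higher number from compound 2 to compound 4 (0.03 log units; within the scatter). Compound 4 is estimated at 23000 nM, with an expected range from 12000 nM to 45000 nM.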

Compound 4, half-maximal cytotoxic concentration: 15200 nM
For compound 4 the middle estimate is 1.5-fold (0.18 log units) above the measured one; measured number inside the range.
By their numbers in this assay, from the lowest: compounds 4, 2 and 1 (each within the scatter of the next). At a limit, above all of these: compound 3.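

In this assay, phenyl to 2-fluorophenyl is the first change shown on this ring of the 1-phenylethyl group, which the earlier compounds left untouched, and it gives a 1.4-fold lower number from compound 2 to compound 4 (0.15 log units; within the scatter). Fluoro on this aromatic carbon, ortho to a large group, therefore moves the number no further than the scatter. Compound 4 gives a measured number, while the one value reported only as a limit belongs to compound 3: the limit of > 47300 nM in this assay, at which 1 of the 4 values shown sits.

As far as these compounds go, whether chloro, methoxy or an amine at this place would move the number beyond the scatter stays open. So does whether fluoro would behave the same way on the glycine-type chain of compound 1.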